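This account rests on a few compounds, and the source may have more. Where it says the series, first, only, none or still open, it means among the compounds named here.

Working notes on the series. The shared core of compound 1 `CC(=O)N[C@@H]1CCC[C@H](C(=O)Nc2cc(-c3cnn4c3CCCC4)c(F)cn2)C1` carries a bicyclic group on the pyridine; in a physicochemical assay for solubility, in phosphate buffer, at pH 7.4 (a higher number here means a more soluble compound, a lower number a less soluble compound), compound 1 reaches only a limit, > 1000000 nM, which is not a number (the limit of > 1000000 nM in this assay, at which 1 of the 3 values shown sits). Compound 2 `CC(=O)N[C@@H]1CCC[C@H](C(=O)Nc2cc(-c3nnn4ccccc34)c(Cl)cn2)C1` gives 530000 nM in this assay. Compound 3 `CC(=O)N[C@@H]1CCC[C@H](C(=O)Nc2cc(-c3cnn4c3CC(C)(C)C4)c(C)cn2)C1` gives 600000 nM in this assay; the values of compound 2 and compound 3 lie within the scatter of each other, so no order between them is claimed. Compound 4 `CC(=O)N[C@@H]1CCC[C@H](C(=O)Nc2cc(-c3cnc4n3CC(C)(C)C4)c(Cl)cn2)C1` has not yet been measured. Relative to compound 2 it differs in one place: a group of 10 heavy atoms (8 carbon, 2 nitrogen; one five-membered non-aromatic ring with 1 hetero atom, one five-membered aromatic ring with 2 hetero atoms) in place of a group of 9 heavy atoms (6 carbon, 3 nitrogen; one five-membered aromatic ring with 3 hetero atoms, one six-membered aromatic ring with 1 hetero atom), on an aromatic carbon. Among the compounds with values here, no measured pair in the set shares this change, so its effect is not directly known; compound 3, which also carries a saturated ring fused to the five-membered aromatic ring, gives 600000 nM, a value close to compound 2. The expectation is a small step from compound 2 to compound 4, if any, downward and likely within the scatter, a 1.3-fold lower number from compound 2 to compound 4 (0.12 log units; within the scatter). Compound 4 is thus estimated at 400000 nM in this assay, with a range from 150000 nM to 1000000 nM.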

Compound 4, solubility: 280000 nM
Compound 4: middle estimate off by 1.4-fold (0.15 log units), on the high side; the range from low to high includes it.
By their numbers in this assay, from the lowest: compounds 4, 2 and 3 (each within the scatter of the next, the first and the last beyond it). At a limit, above all of these: compound 1.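

Within the data shown here, at this position, on an aromatic carbon opposite the ring nitrogen and ortho to a chloro group, a single change can now be read for the first time. In this assay, replacing the group with a five-membered aromatic ring with 3 hetero atoms and a six-membered aromatic ring with 1 hetero atom by the group with a five-membered non-aromatic ring and a five-membered aromatic ring with 2 hetero atoms gives a 1.9-fold lower number from compound 2 to compound 4 (0.28 log units; within the scatter), so this exchange leaves no step beyond the scatter. Nothing measured on hand bears on a cause for this step.

Still open, as far as these compounds go, is how a group carrying an amine or a carboxylic acid at this position would read in this assay. Also open, from the compounds shown here alone, is whether the same exchange gives a similar step with a fluoro or methyl group in place of the chloro group.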